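Triazolylmethyl-substituted spirooxindoles: aryl variation on the triazole

A few compounds are considered here, and "the series" means these few. Any claim that something is new, unique, unknown or untested is made for them only; others in the source may bear on it.

Compound 1 `N#CC1=C(N)Oc2c(N)cc3nc4ccccc4nc3c2C12C(=O)N(Cc1cnnn1-c1cccc(C(F)(F)F)c1)c1ccccc12`: in an ADME assay on HUVEC cells (Homo sapiens) for antiproliferative activity, read by MTT assay, with a stated time of 48 h (a lower number here means a stronger inhibitor, a higher number a weaker inhibitor), compound 1 gives > 50000 nM, which is a limit of the assay and not a number.
Compound 2 `Cc1ccc(-n2nncc2CN2C(=O)C3(C(C#N)=C(N)Oc4c(N)cc5nc6ccccc6nc5c43)c3ccccc32)cc1C`: in this assay compound 2 gives > 50000 nM, again only a limit.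
Compound 3 `CCc1cccc(C)c1-n1nncc1CN1C(=O)C2(C(C#N)=C(N)Oc3c(N)cc4nc5ccccc5nc4c32)c2ccccc21`: in this assay compound 3 gives > 50000 nM, also a limit.

The three measured compounds share one core and differ only in the aryl group on the aromatic nitrogen of the triazole. All three sit at the same limit (the limit of > 50000 nM in this assay, at which 3 of the 3 values shown sit), so no ordering among them can be read. The step that the two limits leave unreadable from compound 1 to compound 2, the step that the two limits leave unreadable from compound 1 to compound 3 and the step that the two limits leave unreadable from compound 2 to compound 3 are all unreadable for this reason; compound 3 stands at the limit together with the other two.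

Compound 4 `N#CC1=C(N)Oc2c(N)cc3nc4ccccc4nc3c2C12C(=O)N(Cc1cnnn1-c1ccc(Cl)cc1Cl)c1ccccc12` is the next member: 2,4-dichlorophenyl in place of 2-ethyl-6-methylphenyl on an aromatic nitrogen. The three measured steps bear on the same position and were all unreadable, so they give no sign that any aryl change there moves the read-out off the limit. The expectation for compound 4 in this assay is therefore a step that the limit leaves unreadable from compound 3 to compound 4 of no readable size. Compound 4 is expected to give 60000 nM, within 30000 nM to 120000 nM, most probably reported as a limit once more.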

Compound 4, half-maximal inhibitory concentration: > 50000 nM
Compound 4: only a limit was reported; the forecaster's own chance of this, stated with the estimate: 85%; the middle value is on the limit's open side.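

In this assay compound 4 gives > 50000 nM, again a limit and not a number. Its steps from compound 1, compound 2 and compound 3 therefore cannot be read, and no new step arises: the limit of > 50000 nM in this assay, at which 4 of the 4 values shown sit.

The compounds shown leave open whether any aryl group on the triazole moves the read-out off this limit, and how these four compounds would rank.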